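Swapping 4-chlorophenyl for a methylated indole

This account rests on a few compounds, and the source may have more. Where it says the series, first, only, none or still open, it means among the compounds named here.

Measured so far in a functional assay on A549 cells (Homo sapiens) for inhibition, read by CCK-8 assay, with a stated time of 48 h; on this read-out higher numbers stand for weaker inhibition and lower numbers for stronger inhibition:
Compound 1 `COc1cc(-c2ccnc3cc(-c4c[nH]c5ccccc45)nn23)cc(OC)c1OC`: 29 nM
Compound 2 `COc1cc(-c2ccnc3cc(-c4ccc(Cl)cc4)nn23)cc(OC)c1OC`: 3070 nM
Compound 3 `COc1cc(-c2ccnc3cc(-c4ccc(C)cc4)nn23)cc(OC)c1OC`: 3 nM

Compound 2 has the highest number of the three, which makes it the weakest inhibitor measured so far. Compound 4 `COc1cc(-c2ccnc3cc(-c4cn(C)c5ccccc45)nn23)cc(OC)c1OC` has not yet been measured. Its difference from compound 2 is 1-methyl-1H-indol-3-yl in place of 4-chlorophenyl on an aromatic carbon.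

The closest evidence is a 110-fold higher number from compound 1 to compound 2 (2.02 log units; beyond the scatter), a large step that would be run in reverse here, since it links the unmethylated indole to the 4-chlorophenyl group. The other two steps, a 9.7-fold lower number from compound 1 to compound 3 (0.99 log units; beyond the scatter) and a 1000-fold lower number from compound 2 to compound 3 (3.01 log units; beyond the scatter), show how widely the values move with the group at this place. For the measured compounds named here, no measured pair shows what the added methyl does. A large fall in the number is therefore expected in this assay, towards compound 1 at 29 nM. The expected change is a 77-fold lower number from compound 2 to compound 4 (1.89 log units; beyond the scatter). For compound 4 the estimate is 40 nM, with an expected range of 6 nM to 300 nM.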

Compound 4, half-maximal inhibitory concentration: 1340 nM
Estimate against measurement, compound 4: 34-fold (1.53 log units) below; the whole stated range lies below it.
By their numbers in this assay, from the lowest: compound 3; then compound 1; then compound 4; then compound 2.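

Within this assay, methyl in place of hydrogen on the aromatic nitrogen of the indole gives a 46-fold higher number from compound 1 to compound 4 (1.66 log units; beyond the scatter) and so removes most of the advantage compound 1 held over the 4-chlorophenyl group. The 1-methyl-1H-indol-3-yl group stands only modestly ahead of 4-chlorophenyl (a 2.3-fold lower number from compound 2 to compound 4 (0.36 log units; beyond the scatter)) and far behind 4-methylphenyl (a 450-fold higher number from compound 3 to compound 4 (2.65 log units; beyond the scatter)), so an indole at this place does not by itself bring the low number of compound 1. Nothing in the data shown gives a reason for these steps.

As far as these compounds go, it remains open how an ethyl or acetyl group on that indole nitrogen would compare with methyl and hydrogen. The compounds also leave open whether a 4-ethylphenyl or 4-methoxyphenyl group would stay close to 4-methylphenyl or fall towards 4-chlorophenyl.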